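Swapping methoxy for nitro on the aniline ring

The source may hold more compounds than are shown below. What is called first, only, known or untested is meant among the compounds shown, and "the series" means these compounds.

Three compounds share a core and were tested in a functional assay on JAR cells (Homo sapiens) for inhibition, read by MTT assay, with a stated time of 72 h, tested at 10 uM; a higher number here means more inhibition at the concentration tested (going by the name of the read-out), a lower number less inhibition. Compound 1 `CCOC(=O)C1=C(Nc2ccccc2)S/C(=C\c2ccc(C(=O)O)cc2)C1=O` gives 16.8%. Compound 2 `CCOC(=O)C1=C(Nc2ccc(OC)cc2)S/C(=C\c2ccc[nH]2)C1=O` gives 27.6%, and compound 3 `CCOC(=O)C1=C(Nc2ccc(OC)c(OC)c2)S/C(=C\c2ccc[nH]2)C1=O` gives 47.9%. Compound 2 therefore stands second highest of the three: compound 1 sits lower by a margin beyond the scatter, and compound 3 sits higher by a margin beyond the scatter. Going by the values given here, the one measured step in this assay, a number 20.3 percentage points higher from compound 2 to compound 3 (beyond the scatter), is modest and concerns a methoxy in place of hydrogen.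

Compound 4 `CCOC(=O)C1=C(Nc2ccc([N+](=O)[O-])cc2)S/C(=C\c2ccc[nH]2)C1=O` differs from compound 2 by nitro in place of methoxy on an aromatic carbon. Among the compounds with values here, no measured step involves a nitro group, so the step from compound 2 to compound 3 gives no direct guide to the direction or size of this change. The expectation therefore rests mainly on compound 2 itself, with a wide range: compound 4 is estimated at 30%, between 10% and 55%, which amounts to an expected step of a number 2.4 percentage points higher from compound 2 to compound 4 (within the scatter).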

Compound 4, a percentage reported as inhibition, at one concentration (the size of the read-out at that concentration, not a potency): 54.9%
Estimate against measurement, compound 4: 24.9 percentage points below; the range from low to high includes it.
By their numbers in this assay, from the lowest: compound 1; then compound 2; then compounds 3 and 4 (each within the scatter of the next).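

In this assay, exchanging 4-methoxyphenyl for 4-nitrophenyl gives a number 27.3 percentage points higher from compound 2 to compound 4 (beyond the scatter) and so shows that this place on the ring is sensitive to the group it carries. The earlier step showed only that adding a second methoxy went with more inhibition, whereas this one shows that methoxy is not required at this place, since nitro in its stead gives more inhibition than compound 2 does. No measurement shown here explains why the nitro group reads higher.

Going by these compounds, what an amine or a nitrile would give at this same place stays open, so two groups cannot establish a trend. On these data alone, it is also open how a plain hydrogen at this place would read with the core of compound 2, which would show whether either group improves on an unsubstituted ring.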